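Fluoro for methyl on a weakly active pair

The source may hold more compounds than are shown below. What is called first, only, known or untested is meant among the compounds shown, and "the series" means these compounds.

Compound 1, `Cc1c(C(=O)Nc2c(F)cc(-c3cccc(F)c3)cc2F)nc2ccc(F)cc2c1O`, gives 7.85% in a functional assay on A-375 cells (Homo sapiens) for antiproliferative activity, read by MTT assay, with a stated time of 24 h, tested at 3.7 ug/mL; a lower number here means a weaker effect, a higher number a stronger effect of the compound at the concentration tested.
Compound 2, `Cc1ccc2nc(C(=O)Nc3c(F)cc(-c4cccc(F)c4)cc3F)c(C)c(C(=O)O)c2c1`, gives 9.25% in this assay.

Compound 2 holds the higher of these two numbers, yet its gap to compound 1 lies within the scatter, so the two cannot be told apart. Compound 3, `Cc1c(C(=O)Nc2c(F)cc(-c3cccc(F)c3)cc2F)nc2ccc(F)cc2c1C(=O)O`, differs from compound 2 in one place: fluoro in place of methyl on an aromatic carbon. Within the data shown here, no measured pair shows this step on its own, and both known numbers are small. The step from compound 2 to compound 3 is therefore expected to be none beyond the scatter, a number 0.3 percentage points lower from compound 2 to compound 3 (within the scatter). Compound 3 is expected to give 9% in this assay, between 2% and 18%.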

Compound 3, a percentage reported as inhibition, at one concentration (the size of the read-out at that concentration, not a potency): 24.5%
For compound 3 the middle estimate is 15.5 percentage points below the measured one; measured number above the stated range.
By their numbers in this assay, from the lowest: compounds 1 and 2 (each within the scatter of the next); then compound 3.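

In this assay, the aromatic carbon bearing fluoro in compound 3 turns out to matter: fluoro in place of methyl there gives a number 15.3 percentage points higher from compound 2 to compound 3 (beyond the scatter). With that fluoro kept, the other site matters too, as carboxy in place of hydroxy gives a number 16.7 percentage points higher from compound 1 to compound 3 (beyond the scatter). Nothing measured here explains either step.

From the compounds shown here alone, whether chloro or an amine on that same aromatic carbon would match fluoro remains open. So does whether a methyl ester or a primary amide could replace the carboxy group.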